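Opening the lactam ring of compound 1

The source may report more compounds than this note shows. Statements on the series, on what has been measured and on what is new or still open speak of the compounds shown alone.

Compound 1 `CC(C)C(c1ccc(-c2ccc3cccc(F)c3c2)[nH]c1=O)N1CCCCC1=O` gives 40 nM in a functional assay on CHO cells for antagonist activity at prostaglandin E2 receptor EP3 subtype (Homo sapiens), read by cAMP accumulation (a lower number here means a stronger inhibitor, a higher number a weaker inhibitor), the lowest of the three numbers shown. Compound 3 `CC(C)C(c1noc(=O)[nH]1)c1ccc(-c2ccc3cccc(F)c3c2)[nH]c1=O` gives 41 nM, and the step of a 1.0-fold higher number from compound 1 to compound 3 (0.01 log units; within the scatter) shows that exchanging the ring on the saturated chain carbon bound to an aromatic carbon and a saturated chain carbon moved nothing beyond the scatter. Compound 2 `CCn1ncc2c(F)cc(-c3ccc(C(CC)(CC)c4nnc(C)[nH]4)c(=O)[nH]3)cc21` gives 90 nM, a weaker result than compound 1 and beyond the scatter. Compound 4 `CC(C)C(CC(N)=O)c1ccc(-c2ccc3cccc(F)c3c2)[nH]c1=O` carries carbamoylmethyl in place of 2-oxopiperidin-1-yl on a saturated chain carbon bound to an aromatic carbon and a saturated chain carbon. For the measured compounds named here, the one measured step at this place, a 1.0-fold higher number from compound 1 to compound 3 (0.01 log units; within the scatter), was flat, so a replacement by a group with no ring is expected to stay near compound 1, with room for a modest weakening. Compound 4 is therefore estimated at 60 nM, in a range from 25 nM to 160 nM, meaning a step of a 1.5-fold higher number from compound 1 to compound 4 (0.18 log units; within the scatter).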

Compound 4, half-maximal inhibitory concentration: 53 nM
Compound 4: the middle estimate sits 1.1-fold (0.05 log units) above what was measured, and the stated range covers the measured number.
By their numbers in this assay, from the lowest: compounds 1, 3, 4 and 2 (each within the scatter of the next, the first and the last beyond it).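

Removing the ring altogether left the number in place: carbamoylmethyl, with no ring, fewer heavy atoms and a hydrogen-bond donor that 2-oxopiperidin-1-yl lacks, held the activity (a 1.3-fold higher number from compound 1 to compound 4 (0.12 log units; within the scatter)). The comparison with the five-membered aromatic ring of compound 3 was equally flat (a 1.3-fold higher number from compound 3 to compound 4 (0.11 log units; within the scatter)), so at this place a ring proved dispensable, whereas the earlier step had only exchanged one ring for another. Nothing shown explains this tolerance.

As far as these compounds go, whether a carboxylic acid, an amine or a longer chain on this carbon would stay as flat remains open. So does how little of the group could remain.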